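Sulfur side chain: 2-hydroxycyclohexyl to 2-carbamoylethyl

The compounds below may be only part of what the source reports. "The series", "measured", "known", "first", "only" and "open" are said of these compounds alone.

In a functional assay on HT cells (Homo sapiens) for antiproliferative activity, read by fluorescence, with a stated time of 72 h (on this read-out lower numbers stand for stronger inhibition of growth and higher numbers for weaker inhibition of growth), compound 1 `CC(C)c1n[nH]c2c(NCc3ccc(-c4ccccn4)cc3)nc(SCC(O)CO)nc12` gives 21 nM, compound 2 `CC(C)c1n[nH]c2c(NCc3ccc(-c4ccccn4)cc3)nc(SCC(O)C(F)(F)F)nc12` gives 690 nM and compound 3 `CC(C)c1n[nH]c2c(NCc3ccc(-c4ccccn4)cc3)nc(SC3CCCCC3O)nc12` gives 636 nM. Compound 3 relates to the other two as follows: a 1.1-fold lower number from compound 2 to compound 3 (0.04 log units; within the scatter), within the scatter, and a 30-fold higher number from compound 1 to compound 3 (1.48 log units; beyond the scatter), beyond it.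

Next is compound 4 `CC(C)c1n[nH]c2c(NCc3ccc(-c4ccccn4)cc3)nc(SCCC(N)=O)nc12`, with 2-carbamoylethyl in place of 2-hydroxycyclohexyl on a sulfur. For the measured compounds named here, no measured compound carries this group, so the evidence is indirect. Two large steps, a 33-fold higher number from compound 1 to compound 2 (1.52 log units; beyond the scatter) and a 30-fold higher number from compound 1 to compound 3 (1.48 log units; beyond the scatter), show that replacing the 2,3-dihydroxypropyl chain can cost much. Losing the ring alone offers no clear gain, since compound 2 also has an open chain and gives 690 nM. Only a modest shift towards stronger inhibition is therefore expected, and it may not clear the scatter. The estimated step is a 2.5-fold lower number from compound 3 to compound 4 (0.41 log units; beyond the scatter). For compound 4 the expected value is 250 nM, with an estimated range of 50 nM to 900 nM.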

Compound 4, concentration for 50% growth inhibition: 120 nM
The estimate for compound 4 lay 2.1-fold (0.32 log units) above the measured number; low and high end bracket the measured number.
By their numbers in this assay, from the lowest: compound 1; then compound 4; then compounds 3 and 2 (each within the scatter of the next).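

In this assay, an open 2-carbamoylethyl chain on the sulfur does better than both earlier replacements of 2,3-dihydroxypropyl (a 5.3-fold lower number from compound 3 to compound 4 (0.72 log units; beyond the scatter); a 5.8-fold lower number from compound 2 to compound 4 (0.76 log units; beyond the scatter)). Among the compounds shown, a hydroxyl on the side chain is therefore not needed to recover part of the loss, although the 2,3-dihydroxypropyl chain still gives the lowest number (a 5.7-fold higher number from compound 1 to compound 4 (0.76 log units; beyond the scatter)). No supporting data are available to explain these differences.

On these data alone, it remains open whether the carbamoyl group itself matters, or whether a carboxylic acid or an amine in its place would give a similar number. As far as these compounds go, the effect of a longer chain carrying the carbamoyl group, and of a 2-hydroxyethyl chain with a single hydroxyl, also remains unknown.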